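The source may hold more compounds than are shown below. What is called first, only, known or untested is meant among the compounds shown, and "the series" means these compounds.

Compounds measured so far, with their numbers in an assay on isolated protein for inhibition of Equilibrative nucleoside transporter 1 (Homo sapiens); a higher number here means a weaker inhibitor, a lower number a stronger inhibitor:

compound 1 `OC[C@H]1O[C@@H](n2cnc3c(SCc4ccccc4I)ncnc32)[C@H](O)[C@@H]1O`: 19.5 nM
compound 2 `N#Cc1ccccc1CSc1ncnc2c1ncn2[C@@H]1O[C@H](CO)[C@@H](O)[C@H]1O`: 38.9 nM
compound 3 `OC[C@H]1O[C@@H](n2cnc3c(SCc4ccc(Cl)cc4Cl)ncnc32)[C@H](O)[C@@H]1O`: 4.37 nM

Compound 3 stands lowest of the three numbers in this assay: a 4.5-fold lower number from compound 1 to compound 3 (0.65 log units; beyond the scatter), and an 8.9-fold lower number from compound 2 to compound 3 (0.95 log units; beyond the scatter). Between the other two the step is small: a 2.0-fold higher number from compound 1 to compound 2 (0.30 log units; within the scatter).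

Compound 4 `Cc1cc(C)c(CSc2ncnc3c2ncn3[C@@H]2O[C@H](CO)[C@@H](O)[C@H]2O)c(C)c1` has not been measured. It differs from compound 3 in one place: 2,4,6-trimethylphenyl in place of 2,4-dichlorophenyl on a saturated chain carbon bound to a sulfur. Going by the values given here, no measured step swaps this same pair of groups. Among the compounds with values here, the steps that bear on it are the two that change the aromatic group on the saturated chain carbon bound to a sulfur, a 4.5-fold lower number from compound 1 to compound 3 (0.65 log units; beyond the scatter) and an 8.9-fold lower number from compound 2 to compound 3 (0.95 log units; beyond the scatter), both modest and both beyond the scatter. They show that the group in this position moves the number in this assay, and that the 2,4-dichlorophenyl gave the lowest number of the three. Leaving that group for 2,4,6-trimethylphenyl is therefore expected to shift the number upward, by a modest step, with wide uncertainty because only a 4.5-fold lower number from compound 1 to compound 3 (0.65 log units; beyond the scatter) and an 8.9-fold lower number from compound 2 to compound 3 (0.95 log units; beyond the scatter) inform the direction. Compound 4 is expected to give about 12 nM in this assay, in a range from 3.5 nM to 45 nM. The expected step is a 2.7-fold higher number from compound 3 to compound 4 (0.44 log units; beyond the scatter).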

Compound 4, inhibition constant: 1910 nM
Beside the measured number, compound 4's estimate is 160-fold (2.20 log units) below it; measured number outside the range, above it.
By their numbers in this assay, from the lowest: compound 3; then compounds 1 and 2 (each within the scatter of the next); then compound 4.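

In this assay, the aromatic group on the saturated chain carbon bound to a sulfur can move the number much further than the earlier modest steps showed, with the 2,4,6-trimethylphenyl giving a large rise (a 440-fold higher number from compound 3 to compound 4 (2.64 log units; beyond the scatter)). The rise is not confined to the comparison with 2,4-dichlorophenyl, as large steps also separate this group from 2-cyanophenyl (a 49-fold higher number from compound 2 to compound 4 (1.69 log units; beyond the scatter)) and from 2-iodophenyl (a 98-fold higher number from compound 1 to compound 4 (1.99 log units; beyond the scatter)). The counts under comparison barely differ, with 9 heavy atoms entering and 8 leaving, one six-membered aromatic ring of carbon only on each side, and 0 hydrogen-bond donors and 0 hydrogen-bond acceptors on each, so such counts do not track the number at this place. No supporting measurement is available to explain the size of this rise.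

Open is whether the rise needs all three methyl groups, since the compounds shown include no unsubstituted phenyl, methylphenyl or dimethylphenyl at this place. Also open, on these data alone, is whether the same order of aromatic groups would hold with an amine in place of the sulfur.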